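This account rests on a few compounds, and the source may have more. Where it says the series, first, only, none or still open, it means among the compounds named here.

Measured in an ADME assay on Vero cells (Chlorocebus sabaeus) for cytotoxicity, read by MTT assay, with a stated time of 72 h; a higher number here means that more compound is tolerated, a lower number that less compound is tolerated:
- Compound 1 `COc1c(N2CCN(CCC#N)C(C)C2)c(F)cc2c(=O)c(C(=O)O)cn(C3CC3)c12`: 500 ug/mL
- Compound 2 `COC(=O)CCN1CCN(c2c(F)cc3c(=O)c(C(=O)O)cn(C4CC4)c3c2OC)CC1C`: > 1000 ug/mL (a limit of the assay)

Compound 2 has no exact number in this assay. Its reading is a limit, (the limit of > 1000 ug/mL in this assay, at which 1 of the 2 values shown sits).

Compound 3 `CCOC(=O)CN1CCN(c2c(F)cc3c(=O)c(C(=O)O)cn(C4CC4)c3c2OC)CC1C` has the same atoms as compound 2, joined differently: ethoxycarbonyl in place of (methoxycarbonyl)methyl on a saturated chain carbon bound to an amine nitrogen in a ring. It carries ethoxycarbonyl in place of (methoxycarbonyl)methyl on a saturated chain carbon bound to an amine nitrogen in a ring. Cut one bond further out, the same difference reads 2-(methoxycarbonyl)ethyl to (ethoxycarbonyl)methyl.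

Within the data shown here, only one measured step comes close to this change, with methoxycarbonyl in place of cyano: an at least 2.0-fold higher number from compound 1 to compound 2 (0.30 log units; that floor lies within the scatter). Among the measured compounds shown here, that step involves a different exchange, and no measured step covers the present one. Its floor also lies within the scatter, so it offers no firm size to carry over. No step beyond the scatter is therefore expected in this assay, and a further limit reading is quite likely. The expected step is a number no higher from compound 2 to compound 3 (the limit leaves the size open).

For compound 3 the estimate is 1000 ug/mL, with an expected range from 500 ug/mL to 2000 ug/mL.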

Compound 3, half-maximal cytotoxic concentration: 1000 ug/mL
Compound 3: middle estimate and measured number agree at the digits printed; the range from low to high includes it.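

In this assay, among these compounds, compound 3 gives the first exact number for an ester-bearing chain at this place, on a saturated chain carbon bound to an amine nitrogen in a ring. Against the nitrile-bearing chain, the exchange of cyanomethyl for ethoxycarbonyl amounts to a 2.0-fold higher number from compound 1 to compound 3 (0.30 log units; within the scatter), so this exchange shows no change beyond the scatter. The reading of compound 2 remains only a limit of the assay. The exchange of (methoxycarbonyl)methyl for ethoxycarbonyl, which keeps the same atoms joined differently, amounts to a number no higher from compound 2 to compound 3 (the limit leaves the size open), and its size cannot be read: the limit of > 1000 ug/mL in this assay, at which 1 of the 3 values shown sits.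

The compounds shown leave open how a free carboxylic acid or an amine at the end of this chain, or a longer chain carrying the same ester, would read in this assay. Also open, going by these compounds, is whether the swap of (methoxycarbonyl)methyl for ethoxycarbonyl has any real size at all, as that would take an exact number for compound 2.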